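A few compounds are considered here, and "the series" means these few. Any claim that something is new, unique, unknown or untested is made for them only; others in the source may bear on it.

Of the compounds shown here, two have been measured in a functional assay on K562 cells (Homo sapiens) for inhibition, read by luminescence, with a stated time of 72 h, tested at 5 uM; a higher number here means more inhibition of growth at the concentration tested, a lower number less inhibition of growth. Compound 1 `C=CS(=O)(=O)NC/C=C/c1cc(OC)cc(O)c1C(=O)OC(C)C` gives 36.2%, and compound 2 `COc1cc(O)c(C(=O)OCC(C)c2ccccc2)c(/C=C/CN2C(=O)C=CC2=O)c1` gives 74.9%. Compound 2 thus stands highest of the two numbers, and its gap to compound 1 lies beyond the scatter. Compound 3 `COc1cc(O)c(C(=O)OC(C)C)c(/C=C/CN2C(=O)C=CC2=O)c1` has not yet been measured. It differs from compound 2 in one place: isopropyl in place of 2-phenylpropyl on an oxygen next to a carbonyl group. In words, isopropyl stands in place of 2-phenylpropyl on an oxygen next to a carbonyl group, and the six-membered aromatic ring of carbon only leaves with it. Within the data shown here, no measured pair shows this change on its own, so its size remains an expectation. Among the measured compounds shown here, the only measured compound with isopropyl is compound 1, which gives 36.2%, but compound 1 also differs from compound 3 elsewhere. A fall in this assay is therefore expected, probably beyond the scatter but smaller than the whole gap between the two measured compounds. The estimated change is a number 19.9 percentage points lower from compound 2 to compound 3 (beyond the scatter). For compound 3 the expected value is 55%, with an estimated range from 33% to 75%.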

Compound 3, percent growth inhibition at one concentration: 95.7%
Estimate against measurement, compound 3: 40.7 percentage points below, and the stated range ends below it.
By their numbers in this assay, from the lowest: compound 1; then compound 2; then compound 3.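

At the position on an oxygen next to a carbonyl group, the change to isopropyl brings no loss in this assay but a number 20.8 percentage points higher from compound 2 to compound 3 (beyond the scatter), so 2-phenylpropyl and its six-membered aromatic ring of carbon only are not required for the growth inhibition of compound 3. With isopropyl the same in both compounds, placing the group with the five-membered non-aromatic ring on the saturated chain carbon, in place of the open-chain group with sulfur, gives a number 59.5 percentage points higher from compound 1 to compound 3 (beyond the scatter), which ties the low value of compound 1 to that open-chain group and not to isopropyl. Nothing further is available to explain either rise.

The compounds shown leave open whether methyl or ethyl on the same oxygen would keep the value of compound 3, and whether a free carboxylic acid or an amide could replace the ester. They also leave open whether the step between 2-phenylpropyl and isopropyl would run the same way with the sulfur-containing group of compound 1, and, with one concentration tested, how far compound 3 with 95.7% would hold its activity at lower concentrations.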